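Swapping the aryl group on the pyrazoline carbon

The compounds below may be only part of what the source reports. "The series", "measured", "known", "first", "only" and "open" are said of these compounds alone.

Of the compounds shown here, three with a shared core have been measured in a functional assay on T47D cells (Homo sapiens) for antiproliferative activity, with a stated time of 48 h; on this read-out lower numbers stand for higher toxicity in this test and higher numbers for lower toxicity in this test. Compound 1 `Cc1cc(O)c(C2=NN(c3ccc(S(N)(=O)=O)cc3)C(c3ccccc3O)C2)cc1Cl` gives 64900 nM. Compound 2 `Cc1cc(O)c(C2=NN(c3ccc(S(N)(=O)=O)cc3)C(c3ccccc3Cl)C2)cc1Cl` gives 82300 nM. Compound 3 `Cc1cc(O)c(C2=NN(c3ccc(S(N)(=O)=O)cc3)C(/C=C/c3ccccc3)C2)cc1Cl` gives 44500 nM, the lowest of the three numbers, though its distance to each neighbour lies within the scatter. The step of a 1.3-fold higher number from compound 1 to compound 2 (0.10 log units; within the scatter) keeps the position of the ring substituent fixed, whereas a 1.5-fold lower number from compound 1 to compound 3 (0.16 log units; within the scatter) and a 1.8-fold lower number from compound 2 to compound 3 (0.27 log units; within the scatter) both exchange the group on a saturated ring carbon, and all three remain within the scatter.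

Compound 4 `COc1ccc(C2CC(c3cc(Cl)c(C)cc3O)=NN2c2ccc(S(N)(=O)=O)cc2)cc1OC` has not yet been measured in this assay. Relative to compound 3 it carries the change (3,4-dimethoxyphenyl in place of 2-phenylethenyl on a saturated ring carbon). The two measured steps that touch the same saturated ring carbon, from compound 1 and from compound 2 to compound 3, were both within the scatter, so an exchange of this group has not yet produced a step beyond it. Among the compounds with values here, no measured pair covers a 3,4-dimethoxyphenyl group here.

Compound 4 is therefore expected to show no step beyond the scatter, that is a 1.1-fold higher number from compound 3 to compound 4 (0.05 log units; within the scatter). Compound 4 is estimated at 50000 nM, with a range from 20000 nM to 130000 nM.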

Compound 4, concentration lethal to 50% of the cells: > 100000 nM
Compound 4 was reported as a limit (the forecaster's own chance of this, stated with the estimate: 10%); middle value at least 2.0-fold (0.30 log units) away from the limit.
By their numbers in this assay, from the lowest: compounds 3, 1 and 2 (each within the scatter of the next). At a limit, above all of these: compound 4.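

In this assay compound 4 gives > 100000 nM, a limit and not a number, and it stands alone there: the limit of > 100000 nM in this assay, at which 1 of the 4 values shown sits. At this saturated ring carbon an exchange of group now produces a step beyond the scatter, an at least 2.2-fold higher number from compound 3 to compound 4 (0.35 log units; beyond the scatter), with 3,4-dimethoxyphenyl in place of 2-phenylethenyl, so on this read-out the position is not indifferent to the group it carries. The other two steps, an at least 1.2-fold higher number from compound 2 to compound 4 (0.08 log units; that floor lies within the scatter) and an at least 1.5-fold higher number from compound 1 to compound 4 (0.18 log units; that floor lies within the scatter), have floors within the scatter, so the 3,4-dimethoxyphenyl group is clearly set apart only from 2-phenylethenyl and not from 2-chlorophenyl or 2-hydroxyphenyl.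

On these data alone, how far compound 4 really lies from the other three remains open, as does whether the methoxy groups account for the step, which a plain phenyl or a single methoxyphenyl group at this carbon could help to separate. The compounds shown also leave open what an amine, a carboxylic acid or a longer chain on this saturated ring carbon would give in this assay.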